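Cyclohexyl to ethyl where every reading is a limit

The compounds below may be only part of what the source reports. "The series", "measured", "known", "first", "only" and "open" are said of these compounds alone.

Measured so far in an ADME assay on BaF3 cells (Mus musculus) for cytotoxicity, read by MTT assay, with a stated time of 48 h (a lower number here means a stronger inhibitor of growth, a higher number a weaker inhibitor of growth), are three compounds:
compound 1 `CC(C)n1nc(-c2cc(C3CCCCC3)on2)c2c(N)ncnc21` gives > 10000 nM as a limit
compound 2 `CC(C)(O)Cn1nc(-c2cc(C3CC3)on2)c2c(N)ncnc21` gives > 10000 nM as a limit
compound 3 `Nc1ncnc2c1c(-c1cc(C3CC3)on1)nn2C1CCOCC1` gives > 10000 nM as a limit

In this assay compound 1 stands at > 10000 nM and this is a limit, not a number. No order can be given among the three compounds, since each of them reads only as a limit.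

Compound 4 `CCc1cc(-c2nn(C(C)C)c3ncnc(N)c23)no1` keeps the core of compound 1 and carries ethyl in place of cyclohexyl on an aromatic carbon with nothing else changed. For the measured compounds named here, the only measured step, a step that the two limits leave unreadable from compound 2 to compound 3 concerns a group on an aromatic nitrogen, so it offers no size to carry over to this change. Compound 4 is expected to read as a limit too, because the limit of > 10000 nM in this assay, at which 3 of the 3 values shown sit, is all the measurements give, and no direction can be expected. The expected outcome is a number no higher from compound 1 to compound 4 (the limit leaves the size open) as estimated here. For compound 4 the estimate is 10000 nM with an expected range from 5000 nM to 20000 nM as its two ends.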

Compound 4, concentration for 50% growth inhibition: > 10000 nM
Compound 4: a limit, no number; the forecaster's own chance of this, stated with the estimate: 85%; the middle value sits exactly at the limit.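

Compound 4 gives > 10000 nM, which is a limit and not a number. For the compounds shown here, compound 1 is also a limit, so no step from compound 1 to compound 4 can be read. The compounds shown leave open what actual number any of them would give in this assay.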